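From One Iodide to Its Nitrile Counterpart

The source may report more compounds than this note shows. Statements on the series, on what has been measured and on what is new or still open speak of the compounds shown alone.

The series rests on a shared dichloroacetamide core, shown for compound 1 as `O=C(Nc1cccc(F)c1)C(Cl)Cl`; in a functional assay on A549 cells (Homo sapiens) for antiproliferative activity, read by MTT assay, with a stated time of 72 h (a higher number here means a weaker inhibitor, a lower number a stronger inhibitor), compound 1 gives "not determined" (no result reported). For the measured compounds named here, compound 2, `O=C(Nc1cccc(I)c1)C(Cl)Cl`, carries the only number in the set: in this assay compound 2 gives 4760 nM. Going by the values given here, with a single measured value there is no ranking to speak of, and no step between measured compounds is available to guide the next one.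

Compound 3, `N#Cc1cccc(NC(=O)C(Cl)Cl)c1`, differs from compound 2 by cyano in place of iodo on an aromatic carbon — cyano in place of iodo on an aromatic carbon, meta to a group of 6 heavy atoms. Nothing measured in this set tells how such an exchange plays out, so the expectation leans on the anchor of compound 2 alone. Compound 3 is estimated to give about 9000 nM in this assay, with a range from 2500 nM to 30000 nM. The step from compound 2 to compound 3 is expected to be modest and toward weaker inhibition, roughly a 1.9-fold higher number from compound 2 to compound 3 (0.28 log units; within the scatter), while the uncertainty is wide.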

Compound 3, half-maximal inhibitory concentration: 66500 nM
The estimate for compound 3 lay 7.4-fold (0.87 log units) below the measured number; the whole stated range lies below it.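

At this place on the aromatic ring the group matters: in this assay putting cyano in place of iodo gives a 14-fold higher number from compound 2 to compound 3 (1.15 log units; beyond the scatter) and so shows that, of these two groups, the iodo goes with the clearly stronger inhibition. For the compounds shown here, this is the first readable step, and it shows that a change of only a few heavy atoms on an aromatic carbon can move the antiproliferative read-out well past ordinary assay variation. Nothing available here accounts for the size of this step.

Steps involving compound 1 cannot be read, so the standing of its fluoro group against iodo and cyano stays unknown. The compounds shown also leave open how a bromo, a methoxy or an amine at this same place would compare with compound 2, and whether any group could outdo iodo.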